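The compounds below may be only part of what the source reports. "The series", "measured", "known", "first", "only" and "open" are said of these compounds alone.

Three compounds share one core, and two of them have been measured so far. In an ADME assay on Vero cells (Chlorocebus sabaeus) for cytotoxicity, read by MTT assay, with a stated time of 72 h (on this read-out higher numbers stand for lower toxicity in this test and lower numbers for higher toxicity in this test), compound 1 (`CCOC(=O)c1c(-c2ccc(OC)cc2)oc2ccc(OCCCCCN3C(=O)/C(=N\OC)c4cc(F)ccc43)cc12`) gives 32 ug/mL and compound 2 (`CCOC(=O)c1c(-c2ccc(OC)cc2)oc2ccc(OCCCCCN3C(=O)/C(=N\O)c4ccccc43)cc12`) gives 64 ug/mL. These two numbers lie within the usual scatter of repeated measurements, so compound 2 cannot be told apart from compound 1. Compound 3 (`CCOC(=O)c1c(-c2ccc(OC)cc2)oc2ccc(OCCCCCN3C(=O)/C(=N\OC)c4ccccc43)cc12`) is compound 2 with methyl in place of hydrogen on an oxygen, an oxygen whose other neighbour is a double-bonded nitrogen, so that hydroxy becomes methoxy: methyl in place of hydrogen on an oxygen. Going by the values given here, no measured pair shows this change on its own, which makes any forecast rough. In this assay, no step beyond the scatter is expected, only a slight drift towards lower numbers, given that compound 1 sits at 32 ug/mL. The expected move is a 1.4-fold lower number from compound 2 to compound 3 (0.15 log units; within the scatter). For compound 3 the estimated value is 45 ug/mL, with an expected range from 20 ug/mL to 100 ug/mL.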

Compound 3, half-maximal cytotoxic concentration: 32 ug/mL
Estimate against measurement, compound 3: 1.4-fold (0.15 log units) above, and the stated range covers the measured number.
By their numbers in this assay, from the lowest: compounds 1, 3 and 2 (each within the scatter of the next).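

In this assay, changing hydroxy to methoxy gives a 2.0-fold lower number from compound 2 to compound 3 (0.30 log units; within the scatter). Going by these compounds alone, this is the first direct view of methyl in place of hydrogen on this oxygen, and at this position the change cannot be told apart from ordinary variation between repeated measurements. Compound 3 also gives a second pair differing in one place, hydrogen in place of fluoro on an aromatic carbon, with no change at the digits printed from compound 1 to compound 3 (within the scatter), so this swap likewise shows no distinguishable effect on the read-out.

Still open, going by these compounds, is whether a larger group on this oxygen, such as ethyl or benzyl, or chloro in place of fluoro on the aromatic carbon, would give a step beyond the scatter. The data at hand also offer no measurement that bears on these results.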